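This account rests on a few compounds, and the source may have more. Where it says the series, first, only, none or still open, it means among the compounds named here.

In a functional assay on DU-145 cells (Homo sapiens) for inhibition, read by trypan blue exclusion, with a stated time of 96 h (on this read-out lower numbers stand for stronger inhibition of growth and higher numbers for weaker inhibition of growth), compound 1 `COc1cc(OC)c(/C=C(/Sc2ccc(C)cc2)C(=O)c2ccc(Cl)cc2)c(OC)c1` reaches only a limit of > 100000 nM and gives no number. For the measured compounds named here, compound 2 `COc1cc(OC)c(/C=C(/SCc2ccc(F)cc2)C(=O)c2ccc(Cl)cc2)c(OC)c1` gives 10000 nM as the only actual number so far. Compound 3 `COc1cc(OC)c(/C=C(\C(=O)c2ccc(Cl)cc2)S(=O)(=O)c2ccc(C)cc2)c(OC)c1` carries (4-methylphenyl)sulfonyl in place of (4-fluorobenzyl)sulfanyl on a double-bonded chain carbon bound to a carbonyl carbon and a double-bonded chain carbon. Going by the values given here, the one measured step at this place (an at least 10-fold lower number from compound 1 to compound 2 (1.00 log units; beyond the scatter)) involves no sulfonyl group, so it fixes neither size nor direction firmly. In this assay a modest move to a lower number is nonetheless expected (a 3.3-fold lower number from compound 2 to compound 3 (0.52 log units; beyond the scatter)) with wide uncertainty. The estimated value for compound 3 is 3000 nM (range 150 nM to 40000 nM).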

Compound 3, concentration for 50% growth inhibition: 25000 nM
Compound 3: the middle estimate sits 8.3-fold (0.92 log units) below what was measured; measured number inside the range.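

In this assay, the sulfonyl group does not extend the move to lower numbers that the (4-fluorobenzyl)sulfanyl group gave, as the change produces a 2.5-fold higher number from compound 2 to compound 3 (0.40 log units; beyond the scatter). With 4-methylphenyl kept, sulfonyl in place of sulfanyl gives an at least 4.0-fold lower number from compound 1 to compound 3 (0.60 log units; beyond the scatter), so the sulfonyl compound still improves on the matching sulfanyl compound. That step is only a bound, since it rests on a limit for compound 1: the limit of > 100000 nM in this assay, at which 1 of the 3 values shown sits.

The compounds shown leave open how the step from compound 2 divides between the sulfur group and the benzyl-to-aryl change. On these data alone, how a (4-fluorobenzyl)sulfonyl group or an amine would read at this place also stays open.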